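This account rests on a few compounds, and the source may have more. Where it says the series, first, only, none or still open, it means among the compounds named here.

Measured compounds:
- compound 1, `O=C(Nc1cccc(-c2oc3cc(-c4ccc(F)cc4)ccc3c(=O)c2O)c1)c1ccccc1F`: 7240 nM
- compound 2, `O=C(Nc1cccc(-c2oc3cc(-c4ccc(F)cc4)ccc3c(=O)c2O)c1)c1ccc(Cl)cc1`: 12800 nM
- compound 3, `O=C(Nc1cccc(-c2oc3cc(-c4ccc(F)cc4)ccc3c(=O)c2O)c1)c1ccc(Br)cc1`: 24900 nM

All three share one core and differ only in the aryl group attached to the carbonyl carbon of the amide. In a functional assay on MDA-MB-231 cells (Homo sapiens) for antiproliferative activity, read by CCK-8 assay, with a stated time of 72 h (a lower number here means a stronger inhibitor, a higher number a weaker inhibitor), compound 3 gives the highest number of the three: its nearest neighbour is compound 2, and the step of a 1.9-fold higher number from compound 2 to compound 3 (0.29 log units; within the scatter) is within the scatter, while the step of a 3.4-fold higher number from compound 1 to compound 3 (0.54 log units; beyond the scatter) is beyond it. Compound 4, `COc1cccc(C(=O)Nc2cccc(-c3oc4cc(-c5ccc(F)cc5)ccc4c(=O)c3O)c2)c1`, is the next compound to be measured. Its difference from compound 3 is 3-methoxyphenyl in place of 4-bromophenyl on a carbonyl carbon.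

Within the data shown here, the steps that bear on this change are those in which the aryl group on the carbonyl carbon was swapped: a 1.8-fold higher number from compound 1 to compound 2 (0.25 log units; within the scatter), a 3.4-fold higher number from compound 1 to compound 3 (0.54 log units; beyond the scatter) and a 1.9-fold higher number from compound 2 to compound 3 (0.29 log units; within the scatter). The largest of them is the one marked modest, so a swap of this kind has so far moved the number only modestly. Among the measured compounds shown here, no measured compound carries a methoxy group, so the direction is uncertain; since compound 3 is the highest number in the set, a lower number is the more likely outcome, and the step of a 2.1-fold lower number from compound 3 to compound 4 (0.32 log units; beyond the scatter) is the expected size. Compound 4 is therefore estimated at 12000 nM, with a range from 4000 nM to 35000 nM.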

Compound 4, half-maximal inhibitory concentration: 9160 nM
For compound 4 the middle estimate is 1.3-fold (0.12 log units) above the measured one; low and high end bracket the measured number.
By their numbers in this assay, from the lowest: compounds 1, 4, 2 and 3 (each within the scatter of the next, the first and the last beyond it).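

In this assay, among these compounds, 3-methoxyphenyl is the only aryl group of the four that counts a hydrogen-bond acceptor, and putting it on the carbonyl carbon in place of 4-bromophenyl gives a 2.7-fold lower number from compound 3 to compound 4 (0.43 log units; beyond the scatter), a modest step and the first one here toward a lower number that lies beyond the scatter. The comparisons with the other two compounds, a 1.4-fold lower number from compound 2 to compound 4 (0.15 log units; within the scatter) and a 1.3-fold higher number from compound 1 to compound 4 (0.10 log units; within the scatter), both lie within the scatter, so compound 4 cannot be separated from compound 2 or compound 1, and this aryl position has tolerated fluoro, chloro and methoxy groups with no clear difference among those three compounds. Nothing measured here accounts for the step from compound 3 to compound 4.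

The change from compound 3 to compound 4 alters both the group on the ring and where it sits, so these compounds cannot show which of the two matters, and 4-methoxyphenyl would be the direct test. From the compounds shown here alone, it also remains open how an amine or a carboxylic acid on this aryl group, or a longer chain in its place, would read in this assay.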